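The source may report more compounds than this note shows. Statements on the series, on what has been measured and on what is new or still open speak of the compounds shown alone.

Measured so far:

compound 1, `O=C(C1CCC1)N1CC2CC(C1)N2`: 240 nM
compound 2, `O=C([C@@H]1C[C@@H]1F)N1CC2CC(C1)N2`: 55 nM

For the measured compounds named here, in an assay on CHO cells for displacement of a labelled ligand from Neuronal acetylcholine receptor; alpha3/alpha6/beta2/beta3 (Homo sapiens), read by scintillation counting (on this read-out higher numbers stand for weaker inhibition and lower numbers for stronger inhibition), compound 2 stands with the lowest of the two numbers measured so far. Its nearest neighbour is compound 1, which gives 240 nM in this assay, and the step of a 4.4-fold lower number from compound 1 to compound 2 (0.64 log units; beyond the scatter) was a modest one and lay beyond the scatter. That step exchanged a cyclobutyl for a 2-fluorocyclopropyl on the carbonyl carbon.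

Compound 3, `C[C@H]1C[C@@H]1C(=O)N1CC2CC(C1)N2`, has not yet been measured. It differs from compound 2 in one place: 2-methylcyclopropyl in place of 2-fluorocyclopropyl on a carbonyl carbon. The ring and its size are kept; only the substituent on that ring changes.

Going by the values given here, only one measured step exists, and it concerns a different exchange, the one from cyclobutyl to the fluorinated ring. Among the compounds with values here, no measured pair swaps fluorine for methyl on the cyclopropyl, so the evidence bears on compound 3 only loosely. Since the three-membered ring is retained, the step of a 1.6-fold higher number from compound 2 to compound 3 (0.21 log units; within the scatter) is expected to be small, within the scatter or a slight rise in the number. Compound 3 is therefore estimated to give 90 nM in this assay, with a range from 30 nM to 270 nM.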

Compound 3, inhibition constant: 310 nM
For compound 3 the middle estimate is 3.4-fold (0.54 log units) below the measured one; the measured number lies above the stated range.
By their numbers in this assay, from the lowest: compound 2; then compounds 1 and 3 (each within the scatter of the next).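

In this assay the group carried on the three-membered ring matters, not only the ring: with the ring kept and its place on the carbonyl carbon unchanged, 2-methylcyclopropyl in place of 2-fluorocyclopropyl gives a 5.6-fold higher number from compound 2 to compound 3 (0.75 log units; beyond the scatter) and so runs opposite to the earlier step from the cyclobutyl. Set against the cyclobutyl, the 2-methylcyclopropyl gives a 1.3-fold higher number from compound 1 to compound 3 (0.11 log units; within the scatter) in the same assay, so the three-membered ring by itself does not go with a lower number, and among these three compounds only the fluorine-bearing compound 2 stands apart from the other two. Nothing available here accounts for the difference between the fluorine and the methyl on this ring.

The compounds shown leave open whether fluorine is specifically required, or whether another small group on the cyclopropyl, such as a hydroxyl, a nitrile or a second fluorine, would keep the lower number. They also leave open how the opposite stereoisomer of the 2-fluorocyclopropyl would read, and whether a fluorine placed on the cyclobutyl would lower the number in the same way.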